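Shortening the acid chain on a shared naphthyl-pyridine core

The source may hold more compounds than are shown below. What is called first, only, known or untested is meant among the compounds shown, and "the series" means these compounds.

Measured in an assay on HEK293 cells for inhibition of solute carrier family 22 member 12 (Homo sapiens), read by scintillation counting, with stated times of 30 min and 15 min; on this read-out lower numbers stand for stronger inhibition and higher numbers for weaker inhibition:
- compound 1, `CC(C)(Sc1ccncc1Oc1ccc(C#N)c2ccccc12)C(=O)O`, gives 5210 nM
- compound 2, `N#Cc1ccc(Oc2cnccc2SCCCCC(=O)O)c2ccccc12`, gives 4220 nM
- compound 3, `N#Cc1ccc(Oc2cnccc2SCCCCCCC(=O)O)c2ccccc12`, gives 3780 nM

Three compounds share one core and differ only in the acid-bearing group on the sulfur. Compound 3 has the lowest number of the three, but the gaps are small: a 1.1-fold lower number from compound 2 to compound 3 (0.05 log units; within the scatter), and a 1.4-fold lower number from compound 1 to compound 3 (0.14 log units; within the scatter), both within the scatter. Likewise a 1.2-fold lower number from compound 1 to compound 2 (0.09 log units; within the scatter). So the chain between sulfur and acid, across these three, has not moved the read-out in any way that can be trusted.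

Compound 4, `N#Cc1ccc(Oc2cnccc2SCCCC(=O)O)c2ccccc12`, is the next step: carboxy in place of 3-carboxypropyl on a saturated chain carbon, three bonds along the chain from a sulfur. Put differently, the same difference cut one bond further out reads 6-carboxyhexyl to 3-carboxypropyl, so compound 4 carries a chain one carbon shorter than compound 2 and three shorter than compound 3. Going by the values given here, the steps that bear on it, from compound 1 to compound 2, from compound 2 to compound 3 and from compound 1 to compound 3, were all within the scatter, so no step beyond the scatter is expected in this assay : the expected step is a 1.2-fold higher number from compound 3 to compound 4 (0.08 log units; within the scatter). Compound 4 is therefore estimated at 4500 nM, with a range from 2000 nM to 10000 nM.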

Compound 4, half-maximal inhibitory concentration: 1230 nM
Compound 4: middle estimate off by 3.7-fold (0.56 log units), on the high side, and the stated range ends above it.
By their numbers in this assay, from the lowest: compound 4; then compounds 3, 2 and 1 (each within the scatter of the next).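

Going by these compounds alone, the acid-bearing group on the sulfur does matter in this assay: with 3-carboxypropyl there, the read-out shows a 3.1-fold lower number from compound 3 to compound 4 (0.49 log units; beyond the scatter) and a 3.4-fold lower number from compound 2 to compound 4 (0.54 log units; beyond the scatter) as the first steps beyond the scatter. The change is not gradual, as 6-carboxyhexyl and 4-carboxybutyl stayed within the scatter of each other and the gain appears only at 3-carboxypropyl. Replacing 1-carboxy-1-methylethyl with 3-carboxypropyl gives the largest step here, a 4.2-fold lower number from compound 1 to compound 4 (0.63 log units; beyond the scatter) but still a modest one, and no supporting data offer an explanation for the drop at this chain length.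

From the compounds shown here alone, whether 2-carboxyethyl or carboxymethyl on the sulfur would lower the number further or raise it again remains open. So does whether the carboxylic acid at the chain end could give way to an amide or a tetrazole and keep the gain seen with compound 4.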